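Replacing an aminophenyl with a methylpyridinyl on a ketone core

The compounds below may be only part of what the source reports. "The series", "measured", "known", "first", "only" and "open" are said of these compounds alone.

Measured so far:
compound 1, `Nc1ccccc1-c1cnc(C(=O)CCCCCCc2ccccc2)o1`, 750 nM
compound 2, `N#Cc1ccccc1-c1cnc(C(=O)CCCCCCc2ccccc2)o1`, 130 nM

Compound 1 gives the highest of the two numbers recorded in an assay (Rattus norvegicus) for inhibition of Fatty-acid amide hydrolase 1 (Homo sapiens); on this read-out higher numbers stand for weaker inhibition and lower numbers for stronger inhibition; its nearest neighbour is compound 2, reached by a 5.8-fold lower number from compound 1 to compound 2 (0.76 log units; beyond the scatter), a change in which cyano replaces amino on an aromatic carbon of the shared core.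

Compound 3, `Cc1ccnc(-c2cnc(C(=O)CCCCCCc3ccccc3)o2)c1`, has not yet been measured. It differs from compound 1 in one place: 4-methylpyridin-2-yl in place of 2-aminophenyl on an aromatic carbon. The group that leaves carries one hydrogen-bond donor and one acceptor; the group that enters carries no donor and one acceptor.

For the measured compounds named here, only one measured step bears on this change. The move from compound 1 to compound 2, a 5.8-fold lower number from compound 1 to compound 2 (0.76 log units; beyond the scatter), also removed the donor of the amino group while keeping an acceptor, and it gave a modest lowering of the number. Compound 3 removes the donor as well, though through a rearranged ring rather than a new substituent, so a lowering of similar size is expected in this assay, with wide uncertainty because the two changes are not alike.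

Compound 3 is therefore expected to give 150 nM, between 30 nM and 750 nM, corresponding to an expected 5.0-fold lower number from compound 1 to compound 3 (0.70 log units; beyond the scatter).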

Compound 3, inhibition constant: 0.6 nM
Compound 3: middle estimate off by 250-fold (2.40 log units), on the high side; the measured number lies below the stated range.
By their numbers in this assay, from the lowest: compound 3; then compound 2; then compound 1.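

In this assay, 4-methylpyridin-2-yl on this aromatic carbon next to the ring oxygen gives a 1300-fold lower number from compound 1 to compound 3 (3.10 log units; beyond the scatter) and also a 220-fold lower number from compound 2 to compound 3 (2.34 log units; beyond the scatter) at the same place on the shared core, so this position can move the number much further than a 5.8-fold lower number from compound 1 to compound 2 (0.76 log units; beyond the scatter) had shown on its own. Compound 2 has already lost the donor of the amino group, yet a large step remains on going to compound 3, so the loss of that donor alone does not track with the size of the change; 2-aminophenyl and 4-methylpyridin-2-yl also have the same atoms, joined differently, so a rearrangement with no change in heavy-atom count is enough to produce the largest step here. No measurement available here gives a reason for this gain. The compounds shown leave open whether the step follows the ring nitrogen, the methyl group or the two together, which unsubstituted pyridin-2-yl and 4-methylphenyl would help to separate. They also leave open whether the gain holds with pyridin-3-yl at this place, or with a shorter chain at the other end of the ketone.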